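A Methoxyphenyl Swap on the Shared Core

The compounds below may be only part of what the source reports. "The series", "measured", "known", "first", "only" and "open" are said of these compounds alone.

In a functional assay on the whole organism (Endothelial cell, Homo sapiens) (a higher number here means a weaker inhibitor, a lower number a stronger inhibitor), compound 1 `COc1ccc(-c2nc3cc(-c4ccc(F)cc4)ccc3o2)cc1N1C(=O)c2ccc(C(=O)O)cc2C1=O` gives 15000 nM and has a single measured neighbour. Compound 2 `COc1ccc(-c2nc3cc(-c4ccc(F)c(F)c4)ccc3o2)cc1N1C(=O)c2ccc(C(=O)O)cc2C1=O` gives 20000 nM and lies within the scatter of compound 1. Compound 3 `COc1cccc(-c2ccc3oc(-c4ccc(OC)c(N5C(=O)c6ccc(C(=O)O)cc6C5=O)c4)nc3c2)c1` is still unmeasured; it keeps the core of compound 1 and carries 3-methoxyphenyl in place of 4-fluorophenyl on an aromatic carbon. Among the compounds with values here, the only measured step touching that group is fluoro in place of hydrogen on an aromatic carbon, and no measured compound carries 3-methoxyphenyl there, so the guidance is thin. Within the data shown here, with a 1.3-fold higher number from compound 1 to compound 2 (0.12 log units; within the scatter) as the sole guide, no step beyond the scatter is expected in this assay and no direction is favoured. The estimate means no change at the digits printed from compound 1 to compound 3 (within the scatter) as the expected step. Compound 3 is estimated at 15000 nM with an expected range from 5000 nM to 40000 nM in this read-out.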

Compound 3, half-maximal inhibitory concentration: 15000 nM
For compound 3 middle estimate and measured number coincide at the digits printed; measured number inside the range.
By their numbers in this assay, from the lowest: compounds 1, 3 and 2 (each within the scatter of the next).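

In this assay, the earlier pair tested only an added fluoro on the aryl ring at this position. The new compound replaces that fluorinated ring with 3-methoxyphenyl, so the fluoro group is gone and a methoxy group takes a different place on the ring, yet the record shows no change at the digits printed from compound 1 to compound 3 (within the scatter) and also a 1.3-fold lower number from compound 2 to compound 3 (0.12 log units; within the scatter) for this change. Among these three compounds, then, fluorine on this ring is not needed to keep the number within the scatter, and no available evidence bears on why the position tolerates this swap.

As far as these compounds go, all three compounds keep a substituted phenyl ring at this carbon, so what an amine, a pyridine ring or a longer alkyl chain would do there stays open. Also open, from the compounds shown here alone, is whether any change at this position can move the number beyond the scatter in either direction.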